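The compounds below may be only part of what the source reports. "The series", "measured", "known", "first", "only" and "open" are said of these compounds alone.

Measured in an ADME assay on MT4 cells (Homo sapiens) for cytotoxicity, read by MTT assay; a lower number here means that less compound is tolerated, a higher number that more compound is tolerated:
Compound 1 `Cc1ccc(N(C(=O)c2cccc(C)c2)C(=S)OCCN2C(=O)c3ccccc3C2=O)cc1`: > 100000 nM
Compound 2 `O=C1c2ccccc2C(=O)N1CCOC(=S)N(C(=O)c1ccc(Cl)cc1Cl)c1ccc(Cl)cc1`: 18000 nM

Compound 1 gives > 100000 nM, which is a limit of the assay and not a number. Within the data shown here, compound 2, at 18000 nM, therefore holds the only actual number so far. Compound 3 `Cc1ccc(N(C(=O)c2ccc(Cl)cc2Cl)C(=S)OCCN2C(=O)c3ccccc3C2=O)cc1` differs from compound 2 by methyl in place of chloro on an aromatic carbon, para to a large group. Among the measured compounds shown here, no measured step shows this change alone. A moderate upward move in this assay is nevertheless expected, with more compound tolerated. The estimated step of a 1.9-fold higher number from compound 2 to compound 3 (0.29 log units; within the scatter) is that move. Compound 3 is expected at 35000 nM, with an estimated range of 15000 nM to 100000 nM.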

Compound 3, half-maximal cytotoxic concentration: 49000 nM
Compound 3: middle estimate off by 1.4-fold (0.15 log units), on the low side, and the stated range covers the measured number.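

In this assay, among these compounds, the change from 4-chlorophenyl to 4-methylphenyl gives the first step between two actual numbers (a 2.7-fold higher number from compound 2 to compound 3 (0.43 log units; beyond the scatter)), beyond the scatter, with more compound tolerated with methyl than with chloro at this place. The second step (an at least 2.0-fold lower number from compound 1 to compound 3 (0.30 log units; that floor lies within the scatter)) gives only a floor, and its starting point is a limit of the assay and not a number: the limit of > 100000 nM in this assay, at which 1 of the 3 values shown sits. The compounds shown leave open how a fluoro or methoxy group would read at this place. They also leave open whether methyl in place of chloro gives a similar step with another group on the carbonyl carbon.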